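The compounds below may be only part of what the source reports. "The series", "measured", "known", "first", "only" and "open" are said of these compounds alone.

Compound 3 `Nc1nc(N)c2c(-c3cccs3)cn([C@@H]3O[C@H](CO)[C@@H](O)[C@H]3O)c2n1` is tested in an ADME assay on MRC5 cells (Homo sapiens), read by MTT assay, with a stated time of 72 h; a lower number here means a stronger inhibitor, a higher number a weaker inhibitor. In this assay compound 3 gives only a limit of the assay, > 100000 nM. Compound 1 `Nc1nc(N)c2c(-c3ccsc3)cn([C@@H]3O[C@H](CO)[C@@H](O)[C@H]3O)c2n1` likewise gives a limit, > 100000 nM. Compound 2 `Cc1nc(N)c2c(-c3ccoc3)cn([C@@H]3O[C@H](CO)[C@@H](O)[C@H]3O)c2n1` also gives a limit, > 100000 nM. Compound 4 `Nc1nc(N)c2c(-c3ccoc3)cn([C@@H]3O[C@H](CO)[C@@H](O)[C@H]3O)c2n1` is not yet measured; it differs from compound 3 in one place: furan-3-yl in place of thiophen-2-yl on an aromatic carbon. Within the data shown here, the one measured step that touches this spot, a step that the two limits leave unreadable from compound 1 to compound 3, runs between two limits and so cannot be read; (the limit of > 100000 nM in this assay, at which 3 of the 3 values shown sit). With no readable step, no change beyond the scatter is expected, and a limit again seems most likely. Compound 4 is expected at 100000 nM, with a range from 30000 nM to 300000 nM. The expected step is a number no higher from compound 3 to compound 4 (the limit leaves the size open).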

Compound 4, half-maximal inhibitory concentration: > 100000 nM
Compound 4 ended at the assay's limit (the forecaster's own chance of this, stated with the estimate: 85%); the middle value sits exactly at the limit.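

In this assay the steps from compound 1, compound 2 and compound 3 to compound 4 cannot be read, because all four compounds give only a limit: the limit of > 100000 nM in this assay, at which 4 of the 4 values shown sit. From the compounds shown here alone, whether these compounds truly differ in this measure, and by how much, stays open.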